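Lengthening the carbonate chain: expected cytotoxicity of compound 3

The compounds below may be only part of what the source reports. "The series", "measured", "known", "first", "only" and "open" are said of these compounds alone.

compound 1 `CC(C)COC(=O)OCC(CO)CCn1cnc2cnc(N)nc21`: > 500000 nM
compound 2 `CCCOC(=O)OCC(CO)CCn1cnc2cnc(N)nc21`: > 500000 nM

In a functional assay on Vero cells (Chlorocebus sabaeus) for cytotoxicity (on this read-out lower numbers stand for higher toxicity in this test and higher numbers for lower toxicity in this test), compound 1 gives > 500000 nM, which is a limit of the assay. In the same test compound 2 gives > 500000 nM, again only a limit. The step that the two limits leave unreadable from compound 1 to compound 2 is therefore not readable, since both values sit at the limit of > 500000 nM in this assay, at which 2 of the 2 values shown sit. Compound 3 `CCCCCOC(=O)OCC(CO)CCn1cnc2cnc(N)nc21` differs from compound 2 by ethyl in place of hydrogen on a saturated chain carbon, three bonds along the chain from an oxygen next to a carbonyl group. Among the compounds with values here, no measured step gives a readable size in this test, so no shift beyond the scatter is expected, the estimated step being a step that the limit leaves unreadable from compound 2 to compound 3. Compound 3 is thus expected near 600000 nM, between 250000 nM and 2000000 nM, most likely reported once more only as a limit.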

Compound 3, half-maximal cytotoxic concentration: > 500000 nM
Compound 3: only a limit was reported; the forecaster's own chance of this, stated with the estimate: 85%; the middle value is on the limit's open side.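

Compound 1, compound 2 and compound 3 each give only a limit in this assay, so no step among them can be read: the limit of > 500000 nM in this assay, at which 3 of the 3 values shown sit.

The compounds shown leave open whether changing the chain shifts the cytotoxicity of these compounds at all.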